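One Stereocentre Inverted at Compound 3

The source may report more compounds than this note shows. Statements on the series, on what has been measured and on what is new or still open speak of the compounds shown alone.

Compound 1 (`COc1cc(-c2nc3ccccc3s2)ccc1OCC(=O)NNC(=O)CN[C@@H](CS)C(=O)O`) gives 1230 nM
Compound 2 (`COc1cc(-c2nc3ccccc3s2)ccc1OCC(=O)NNC(=O)CN[C@@H](CCSC)C(=O)O`) gives 1950 nM
Compound 3 (`CCOC(=O)[C@@H](NCC(=O)NNC(=O)COc1ccc(-c2nc3ccccc3s2)cc1OC)[C@@H](C)CC`) gives 1950 nM

In a functional assay on MCF7 cells (Homo sapiens) for inhibition, read by MTT assay, with a stated time of 3 days (a lower number here means a stronger inhibitor, a higher number a weaker inhibitor), compound 3 gives 1950 nM and stands level with compound 2, together the highest of the three numbers, all within the scatter of one another. Compound 4 (`CCOC(=O)[C@H](NCC(=O)NNC(=O)COc1ccc(-c2nc3ccccc3s2)cc1OC)[C@@H](C)CC`) departs from compound 3 in configuration alone (the two compounds have the same atoms and bonds and differ only in configuration as drawn: 1 of 2 stereo elements differ; a stereocentre at a saturated chain carbon is drawn S in compound 3 and R in compound 4). Going by the values given here, no measured pair isolates such a change. The nearest evidence is the replacement of the whole substituent on the amine nitrogen, which left little mark (a 1.6-fold higher number from compound 1 to compound 3 (0.20 log units; within the scatter)) and (no change at the digits printed from compound 2 to compound 3 (within the scatter)). The expected step is therefore small (a 1.1-fold higher number from compound 3 to compound 4 (0.03 log units; within the scatter)) and none beyond the scatter is expected. The estimate for compound 4 is 2100 nM (expected range 1000 nM to 4200 nM).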

Compound 4, half-maximal inhibitory concentration: 2900 nM
The estimate for compound 4 lay 1.4-fold (0.14 log units) below the measured number, and the stated range covers the measured number.
By their numbers in this assay, from the lowest: compounds 1, 2, 3 and 4 (each within the scatter of the next, the first and the last beyond it).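

In this assay, going by these compounds alone, the first step that isolates configuration at this saturated chain carbon is a 1.5-fold higher number from compound 3 to compound 4 (0.17 log units; within the scatter), so the form drawn R cannot be told from the form drawn S. With the R form of 1-(ethoxycarbonyl)-2-methylbutyl on the amine nitrogen, replacing 1-carboxy-3-(methylsulfanyl)propyl gives a 1.5-fold higher number from compound 2 to compound 4 (0.17 log units; within the scatter), while replacing 1-carboxy-2-sulfanylethyl gives a 2.4-fold higher number from compound 1 to compound 4 (0.37 log units; beyond the scatter), the only one of these new steps beyond the scatter. The reading of configuration rests on a single clean pair: the fact that compounds 3 and 4 differ only in the configuration as drawn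

From the compounds shown here alone, whether inversion at this carbon would read the same with a primary amide in place of the ethoxycarbonyl group stays open, as does the effect of inverting the other stereocentre.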